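Swapping the Dimethylpyrazole Pattern on a Kinase Inhibitor

The source may report more compounds than this note shows. Statements on the series, on what has been measured and on what is new or still open speak of the compounds shown alone.

Compound 1 `Cc1c(Nc2nc(N)c3c(C#N)c(N4CCC[C@H]4C)n(C)c3n2)cnn1C` gives 2 nM in an assay on isolated protein for binding affinity to Leucine-rich repeat serine/threonine-protein kinase 2 (Homo sapiens), read by TR-FRET and LanthaScreen, with a stated time of 2 h (a higher number here means a weaker inhibitor, a lower number a stronger inhibitor), the lowest of the two numbers recorded. Compound 2 `C[C@@H]1CCCN1c1c(C(N)=O)c2c(N)ncnc2n1C` gives 77 nM in this assay, a gap beyond the scatter. Compound 3 `Cc1nn(C)cc1Nc1nc(N)c2c(C#N)c(N3CCC[C@H]3C)n(C)c2n1` differs from compound 1 by 1,3-dimethyl-1H-pyrazol-4-yl in place of 1,5-dimethyl-1H-pyrazol-4-yl on a nitrogen on an aromatic ring. Within the data shown here, no step between two measured compounds of this kind has been recorded, so the size of this step in this assay is uncertain; the two compounds have the same atoms joined differently, and a change within the scatter or a modest weakening is expected. Compound 3 is estimated at 3 nM, with a range from 1 nM to 10 nM. The expected step is a 1.5-fold higher number from compound 1 to compound 3 (0.18 log units; within the scatter).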

Compound 3, inhibition constant: 1 nM
Compound 3: the middle estimate sits 3.0-fold (0.48 log units) above what was measured, within the range that was stated.
By their numbers in this assay, from the lowest: compounds 3 and 1 (each within the scatter of the next); then compound 2.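

In this assay, among these compounds, 1,3-dimethyl-1H-pyrazol-4-yl in place of 1,5-dimethyl-1H-pyrazol-4-yl on a nitrogen on an aromatic ring gives a 2.0-fold lower number from compound 1 to compound 3 (0.30 log units; within the scatter) and this is the first step that can be read at this position. The two dimethylpyrazole patterns cannot be told apart by this read-out, so this position accepts either arrangement of the same atoms. No evidence at hand bears on why the two patterns read alike. Going by these compounds, what an unsubstituted pyrazol-4-yl, a phenyl or a morpholine on that nitrogen would give remains open.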